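Same Carbamate Chain Added to Two Different Cores

The source may hold more compounds than are shown below. What is called first, only, known or untested is meant among the compounds shown, and "the series" means these compounds.

Compound 1 `CCCn1c(NC(=O)c2cc(C)nn2CC)nc2cc(C(=O)OC)cc(OC)c21` and compound 3 `CCn1nc(C)cc1C(=O)Nc1nc2cc(C(=O)OC)cc(OC)c2n1CCCNC(=O)OCc1ccccc1` share one core and differ only by (benzyloxycarbonyl)amino in place of hydrogen on a saturated chain carbon, three bonds along the chain from an aromatic nitrogen. In an assay for activation of interferon regulatory factor 3 (Homo sapiens), read by a luciferase reporter, with a stated time of 20 h (on this read-out lower numbers stand for an effect already at smaller amounts and higher numbers for an effect only at larger amounts of compound), compound 1 gives only a limit, > 100000 nM. In this assay compound 3 gives 27600 nM. The step is an at least 3.6-fold lower number from compound 1 to compound 3 (0.55 log units; beyond the scatter), and because its starting point is a limit, (the limit of > 100000 nM in this assay, at which 2 of the 3 values shown sit), only a lower bound on its size can be read.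

Compound 2 `CCCn1c(NC(=O)c2ccc3ccccc3n2)nc2cc(C(N)=O)cc(OC)c21` carries a different core; the difference between the two cores is not broken down here. In this assay compound 2 gives only a limit, > 100000 nM. Compound 4 `COc1cc(C(N)=O)cc2nc(NC(=O)c3ccc4ccccc4n3)n(CCCNC(=O)OCc3ccccc3)c12` is compound 2 with the same change, ((benzyloxycarbonyl)amino in place of hydrogen on a saturated chain carbon, three bonds along the chain from an aromatic nitrogen), at the same place as in compound 3.

For compound 4 a step of an at least 2.8-fold lower number from compound 2 to compound 4 (0.45 log units; beyond the scatter) is expected, resting on an at least 3.6-fold lower number from compound 1 to compound 3 (0.55 log units; beyond the scatter), where the same change moved a compound from the limit to a number. From the compounds shown here alone, whether the change carries over to the second core is untested, so the range is wide. Compound 4 is estimated at 35000 nM, between 8000 nM and 150000 nM.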

Compound 4, half-maximal effective concentration: > 100000 nM
Compound 4: only a limit was reported (the forecaster's own chance of this, stated with the estimate: 45%); middle value at least 2.8-fold (0.45 log units) from the limit.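

In this assay compound 4 gives only a limit, > 100000 nM. Compound 2 is also a limit, so no step can be read between compound 2 and compound 4: the limit of > 100000 nM in this assay, at which 3 of the 4 values shown sit.

From the compounds shown here alone, whether (benzyloxycarbonyl)amino in place of hydrogen changes anything on the core of compound 2, as it did on the core of compound 1, stays open.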